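This account rests on a few compounds, and the source may have more. Where it says the series, first, only, none or still open, it means among the compounds named here.

In a functional assay on HUVEC cells (Homo sapiens), read by scintillation counting and thymidine incorporation, with a stated time of 24 h (on this read-out lower numbers stand for stronger inhibition and higher numbers for weaker inhibition), compound 1 `CCC(C)n1ncn(-c2ccc(N3CCN(c4ccc(OC[C@@H]5CO[C@@](CC6CCCC6)(c6ccc(Cl)cc6Cl)O5)cc4)CC3)cc2)c1=O`, with cyclopentyl on a saturated chain carbon bound to a saturated ring carbon, gives 512 nM. At that place, compound 2 `CCC(C)n1ncn(-c2ccc(N3CCN(c4ccc(OC[C@@H]5CO[C@@](Cn6cnc(C)n6)(c6ccc(Cl)cc6Cl)O5)cc4)CC3)cc2)c1=O` carries 3-methyl-1H-1,2,4-triazol-1-yl and gives 272 nM. Compound 3 `CCC(C)n1ncn(-c2ccc(N3CCN(c4ccc(OC[C@@H]5CO[C@@](Cn6nc(C)nc6C)(c6ccc(Cl)cc6Cl)O5)cc4)CC3)cc2)c1=O` carries 3,5-dimethyl-1H-1,2,4-triazol-1-yl and gives 221 nM. Compound 3 therefore sits level with compound 2 within the scatter and modestly clear of compound 1. The cyclopentyl replacements gave a 1.9-fold lower number from compound 1 to compound 2 (0.27 log units; within the scatter) and a 2.3-fold lower number from compound 1 to compound 3 (0.36 log units; beyond the scatter), while the added methyl gave a 1.2-fold lower number from compound 2 to compound 3 (0.09 log units; within the scatter).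

Compound 4 `CCC(C)n1ncn(-c2ccc(N3CCN(c4ccc(OC[C@@H]5CO[C@@](Cn6cnc(C(F)(F)F)n6)(c6ccc(Cl)cc6Cl)O5)cc4)CC3)cc2)c1=O` differs from compound 3 as follows: 3-(trifluoromethyl)-1H-1,2,4-triazol-1-yl in place of 3,5-dimethyl-1H-1,2,4-triazol-1-yl on a saturated chain carbon bound to a saturated ring carbon. For the measured compounds named here, no measured compound carries trifluoromethyl, so the closest guide is the small methyl step between the two triazolyl compounds, and a step beyond the scatter is not expected. The expected change is a 1.1-fold higher number from compound 3 to compound 4 (0.05 log units; within the scatter), which carries wide uncertainty. The estimate for compound 4 is 250 nM, with an expected range of 110 nM to 520 nM.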

Compound 4, half-maximal inhibitory concentration: 270 nM
The estimate for compound 4 lay 1.1-fold (0.03 log units) below the measured number; measured number inside the range.
By their numbers in this assay, from the lowest: compounds 3, 4, 2 and 1 (each within the scatter of the next, the first and the last beyond it).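

In this assay, trifluoromethyl on the aromatic carbon of the triazolyl group can stand in for methyl without a readable shift: the swap gives a 1.0-fold lower number from compound 2 to compound 4 (0.00 log units; within the scatter), and the change from the dimethyl group gives a 1.2-fold higher number from compound 3 to compound 4 (0.09 log units; within the scatter). This extends the earlier picture to a larger triazolyl group, with 9 heavy atoms against 7, and shows that this place tolerates more than the two methyl-bearing triazolyl groups. Against cyclopentyl, the new group gives a 1.9-fold lower number from compound 1 to compound 4 (0.28 log units; within the scatter), so of the three triazolyl compounds only compound 3 stands clear of compound 1. No measurement here offers an explanation for this flat result.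

The compounds shown leave open whether an amine or a carboxylic acid on that aromatic carbon would keep the number in this range. They also leave open how the unsubstituted 1H-1,2,4-triazol-1-yl group would read.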